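The source may hold more compounds than are shown below. What is called first, only, known or untested is meant among the compounds shown, and "the series" means these compounds.

In a functional assay on HL-60 cells (Homo sapiens) for antiproliferative activity, tested at 20 uM (a higher number here means a stronger effect of the compound at the concentration tested, a lower number a weaker effect), compound 1, the compound `COc1ccc(C(=O)NOCc2ccccc2)cc1S(=O)(=O)Nc1ccc2c(c1)cc(C)c(=O)n2C`, gives 13%. Two companions sharing the same core were run alongside it. Compound 2, `Cc1cc2cc(NS(=O)(=O)c3ccc(C(=O)NO)cc3)ccc2n(C)c1=O`, gives 6% in this assay, and compound 3, `COC(=O)c1ccc(CS(=O)(=O)Nc2ccc3c(c2)cc(C)c(=O)n3C)cc1`, gives 14%. The number for compound 1 therefore sits among the other two: the difference to compound 3 is a single point and the difference to compound 2 is seven points, and both of these gaps lie within the usual scatter of repeated measurements, so none of the three can be set apart from the others on the numbers in hand.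

Compound 4, `COc1ccc(C(=O)NO)cc1S(=O)(=O)Nc1ccc2c(c1)cc(C)c(=O)n2C`, differs from compound 1 in one place: hydrogen in place of benzyl on an oxygen. Among the compounds with values here, no measured pair in this set shows this change on its own, so there is nothing that tells directly what it does in this assay. With all three measured compounds standing within the scatter of one another, the expectation is that compound 4 will land in the same region, with no step beyond the scatter. Compound 4 is expected to give about 10%, in a range from 0% to 25%. The estimated step of a number 3 percentage points lower from compound 1 to compound 4 (within the scatter) is expected to stay within the scatter.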

Compound 4, a percentage reported as inhibition, at one concentration (the size of the read-out at that concentration, not a potency): 10%
Beside the measured number, compound 4's estimate shows no gap at the digits printed, and the stated range covers the measured number.
By their numbers in this assay, from the lowest: compounds 2, 4, 1 and 3 (each within the scatter of the next).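

Within the data shown here, the step of a number 3 percentage points lower from compound 1 to compound 4 (within the scatter) is the first direct reading of this position in this assay and it shows that removing the benzyl, with its 7 carbon atoms and its six-membered aromatic ring, from the oxygen on the amide-type nitrogen leaves the read-out within the scatter. The earlier compounds shown here could set compound 1 only beside companions that differ from it in more than one place, whereas this pair isolates the change from (benzyloxy)carbamoyl to hydroxycarbamoyl on an otherwise unchanged structure, and at the single concentration tested the two forms cannot be told apart. Nothing available bears on why the two compounds read alike.

Still open, on these data alone, is whether another group on this oxygen, such as methyl or a longer alkyl chain, would give a step beyond the scatter, and whether a carboxylic acid or a primary amide in place of the hydroxycarbamoyl would do so. The compounds shown also leave open whether compound 1 and compound 4 would separate at another concentration, since a read-out at one concentration is not a potency.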